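Phenylsulfonyl for 6-hydroxyhexyl on the compound 1 scaffold

This account rests on a few compounds, and the source may have more. Where it says the series, first, only, none or still open, it means among the compounds named here.

Measured so far in an assay on cells for binding affinity to vitamin D3 receptor (Homo sapiens), read by fluorescence, tested at 1 uM; on this read-out lower numbers stand for less inhibition and higher numbers for more inhibition at the one concentration tested (going by the name of the read-out):
compound 1, `CCC(CC)(c1ccc(OCCCCCCO)c(C)c1)c1ccc(OCC(O)C(C)(C)C)c(OCC(O)C(C)(C)C)c1`, 52%
compound 2, `CCC(CC)(c1ccc(OCCCC(=O)O)c(C)c1)c1ccc(OCC(O)C(C)(C)C)c(OCC(O)C(C)(C)C)c1`, 14%
compound 3, `CCC(CC)(c1ccc(OCCCCC(=O)O)c(C)c1)c1ccc(OCC(O)C(C)(C)C)c(OCC(O)C(C)(C)C)c1`, "not active" (no number reported)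

Compound 1 stands highest of the two numbers in this assay. Its nearest neighbour is compound 2, reached by a number 38 percentage points lower from compound 1 to compound 2 (beyond the scatter), a large drop that lies beyond the scatter. Compound 3 returned no number at all in this assay and is reported only as inactive, so it cannot be placed on the scale.

Compound 4, `CCC(CC)(c1ccc(OS(=O)(=O)c2ccccc2)c(C)c1)c1ccc(OCC(O)C(C)(C)C)c(OCC(O)C(C)(C)C)c1`, is not yet measured. Relative to compound 1 the change is phenylsulfonyl in place of 6-hydroxyhexyl on an oxygen on an aromatic ring. Among the measured compounds shown here, the single measured step that bears on this position, from compound 1 to compound 2, replaced the end of the chain on this oxygen and cost a large part of the inhibition; compound 3, altered at the same chain, gave no number. Every recorded change at this oxygen has therefore moved the read-out downward, and the change to compound 4 is more extensive than either. For the measured compounds named here, a sizeable fall is expected, a number 27 percentage points lower from compound 1 to compound 4 (beyond the scatter), with real uncertainty because the new group has no precedent.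

Compound 4 is estimated at 25%, within a range from 5% to 50%, in this assay.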

Compound 4, a percentage reported as inhibition, at one concentration (the size of the read-out at that concentration, not a potency): "not active" (no number reported)
For compound 4 the study gives words and no number, and the estimate cannot be compared.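

Among the compounds shown here, compound 4 is reported in this assay only as "not active", with no number, so no step from compound 1 can be read. The compounds shown leave open how compound 4 and compound 3, both without a number, stand relative to compound 2 on this scale. No measured evidence bears on this result.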